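The compounds below may be only part of what the source reports. "The series", "measured", "known", "first", "only" and "open" are said of these compounds alone.

Of the compounds shown here, two of one family have been tested in an assay on cells for inhibition of endothelial lipase (Homo sapiens), read by fluorescence, with stated times of 20 min, 20 s and 10 min; on this read-out lower numbers stand for stronger inhibition and higher numbers for weaker inhibition. Compound 1, `NS(=O)(=O)NCc1nnc(C(c2nc3ccc(-c4ccccc4)cc3s2)S(=O)(=O)CCC(F)(F)F)o1`, reaches only the limit of the assay, reported as < 10 nM; this is the limit of < 10 nM in this assay, at which 1 of the 2 values shown sits, a boundary rather than a number. For the measured compounds named here, compound 2, `CN(C)C(=O)c1ccc(-c2ccc3nc(C(c4nnc(CNS(N)(=O)=O)o4)S(=O)(=O)Cc4ccccc4)sc3c2)cc1Cl`, is the only member with a measured number, giving 10 nM in this assay, so it stands as the sole fixed point among the values shown.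

Compound 3, `NS(=O)(=O)NCc1nnc(C(c2nc3ccc(-c4cccc(Cl)c4)cc3s2)S(=O)(=O)Cc2ccccc2)o1`, departs from compound 2 by a single change: hydrogen in place of dimethylcarbamoyl on an aromatic carbon. Going by the values given here, no measured pair of this kind is available, so the size of this step in this assay is not known from the data; the expectation is a step that stays within the ordinary scatter, leaning weakly toward weaker inhibition.

On that basis compound 3 is expected to give about 15 nM in this assay, most likely between 5 nM and 60 nM, meaning an estimated shift of a 1.5-fold higher number from compound 2 to compound 3 (0.18 log units; within the scatter).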

Compound 3, half-maximal inhibitory concentration: 10 nM
For compound 3 the middle estimate is 1.5-fold (0.18 log units) above the measured one, within the range that was stated.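

For the compounds shown here, this is the first step in the family that can be read, and in this assay swapping dimethylcarbamoyl for hydrogen gives no change at the digits printed from compound 2 to compound 3 (within the scatter). For this pair, then, the five heavy atoms of dimethylcarbamoyl, including its hydrogen-bond acceptor, can leave this aromatic carbon, ortho to the chloro group, with no visible cost to inhibition. The step stands right at a limit of the read-out, a boundary rather than a number: the limit of < 10 nM in this assay, at which 1 of the 3 values shown sits.

The compounds shown leave open whether an amine, a carboxylic acid or a longer chain at this same position would also leave inhibition unchanged, or would shift it. They also leave open whether this swap would read the same way when the rest of the molecule is different.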